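The source may hold more compounds than are shown below. What is called first, only, known or untested is meant among the compounds shown, and "the series" means these compounds.

Measured so far:
Compound 1, `O=C(c1ccc(F)cc1)N1CC(c2nc(-c3cccc(Cl)c3)no2)C1`: in an assay on HEK293 cells for negative allosteric modulation of metabotropic glutamate receptor 5 (Homo sapiens), read by FLIPR (on this read-out lower numbers stand for stronger inhibition and higher numbers for weaker inhibition), compound 1 gives 4000 nM
Compound 2, `Cc1ccc(S(=O)(=O)N2CC(c3nc(-c4cccc(C)c4)no3)C2)cc1`: in this assay compound 2 gives 670 nM

Compound 1 carries the highest of the two numbers recorded in this assay. Its nearest neighbour is compound 2, whose number is lower, and the gap between the two lies beyond the usual scatter of repeated measurements; since compound 2 differs from compound 1 in more than one place, the two values say nothing about any single change.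

Compound 3, `CC1CN(C(=O)N2CC(c3nc(-c4cccc(Cl)c4)no3)C2)CC(C)O1`, has not yet been measured in this assay. It departs from compound 1 in one place: 2,6-dimethylmorpholin-4-yl in place of 4-fluorophenyl on a carbonyl carbon. Within the data shown here, no pair of measured compounds separated by one change is available, so there is no measured step to lean on for this replacement. Given only that compound 1 stands at 4000 nM in this assay, the step of a 1.3-fold lower number from compound 1 to compound 3 (0.12 log units; within the scatter) is expected to be small, not clearly beyond the scatter in either direction. Compound 3 is therefore estimated at 3000 nM in this assay, with a range from 800 nM to 12000 nM.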

Compound 3, half-maximal inhibitory concentration: 990 nM
Compound 3: middle estimate off by 3.0-fold (0.48 log units), on the high side, and the stated range covers the measured number.
By their numbers in this assay, from the lowest: compounds 2 and 3 (each within the scatter of the next); then compound 1.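

In this assay, among these compounds, the one single-place change available on the carbonyl carbon gives a 4.0-fold lower number from compound 1 to compound 3 (0.61 log units; beyond the scatter) when 2,6-dimethylmorpholin-4-yl takes the place of 4-fluorophenyl. Among the compounds shown here, this is the first reading of this position on its own, since the gap between compound 1 and compound 2 could not be tied to any one change; on the core of compound 1, the six-membered aromatic ring of carbon can give way to a non-aromatic ring with 2 hetero atoms without the number rising, and the number in fact falls beyond the scatter. No independent measurement accompanies this step, so the data offer no account of why the number falls.

The compounds shown leave open which feature of the 2,6-dimethylmorpholin-4-yl group goes with the step: its ring oxygen, its two methyl groups, or the non-aromatic ring itself. Whether a plain morpholin-4-yl, a piperidin-1-yl or an open-chain dimethylamino group on the same carbonyl carbon would stand nearer to compound 3 or to compound 1 also remains unanswered.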